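Amine swap at the aniline ring: compound 1 to compound 4

This account rests on a few compounds, and the source may have more. Where it says the series, first, only, none or still open, it means among the compounds named here.

The measured compounds in an assay on isolated protein for inhibition of NUAK family SNF1-like kinase 1 (Homo sapiens), read by ADP-Glo, with a stated time of 60 min, tested at 10 uM, in the presence of a further agent that is not named here; a higher number here means more inhibition at the concentration tested (going by the name of the read-out), a lower number less inhibition:
Compound 1, `CCC(=O)Nc1cccc(Oc2nc(Nc3ccc(N(C)C)cc3OC)ncc2Cl)c1`, gives 80.6%.
Compound 2, `CCC(=O)Nc1cccc(Oc2nc(Nc3ccc(N4CCN(C)CC4)cc3)ncc2Cl)c1`, gives 92.9%.
Compound 3, `CCC(=O)Nc1cccc(Oc2nc(Nc3ccc(N4CCCCC4)cc3)ncc2Cl)c1`, gives 86%.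

Compound 1 holds the lowest of the three numbers. Its distance to compound 3 lies within the scatter, so those two cannot be ordered; only compound 2 stands beyond the scatter above it.

Compound 4, `CCCN(CCC)c1ccc(Nc2ncc(Cl)c(Oc3cccc(NC(=O)CC)c3)n2)c(OC)c1`, has not yet been measured. It differs from compound 1 in one place: dipropylamino in place of dimethylamino on an aromatic carbon, on an aromatic carbon of a six-membered aromatic ring of carbon only.

Within the data shown here, only one measured step is available for comparison, a number 6.9 percentage points lower from compound 2 to compound 3 (within the scatter). That step exchanges one ring amine for another on the same aromatic carbon of the shared core, and it moved the number by an amount within the scatter. It is not the same kind of change as lengthening an open-chain amine, but it is the nearest guide, and it suggests that changes at this position have so far left the inhibition roughly where it was.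

The expected step of a number 0.6 percentage points lower from compound 1 to compound 4 (within the scatter) is therefore none beyond the scatter. Compound 4 is estimated at 80%, within a range from 66% to 92%.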

Compound 4, a percentage reported as inhibition, at one concentration (the size of the read-out at that concentration, not a potency): "not active" (no number reported)
Compound 4: no number reported, so the estimate cannot be set against anything.
By their numbers in this assay, from the lowest: compounds 1, 3 and 2 (each within the scatter of the next, the first and the last beyond it).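

In this assay, among these compounds, compound 4 is reported as "not active" with no number, so no step from compound 1 to compound 4 can be read. The compounds shown leave open how large a change dipropylamino in place of dimethylamino brings. Nothing measured here offers an explanation for this result.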